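The source may hold more compounds than are shown below. What is called first, only, known or untested is meant among the compounds shown, and "the series" means these compounds.

Measured so far in an ADME assay on MT4 cells (Homo sapiens) for cytotoxicity, read by MTT assay; on this read-out higher numbers stand for lower toxicity in this test and lower numbers for higher toxicity in this test: compound 1 `Cc1ccc(NC(=S)OCCc2ccccn2)cc1` gives 75000 nM, and compound 2 `CN(C)c1ccc(NC(=S)OCCc2ccccn2)cc1` gives 60000 nM. For compound 3 `O=[N+]([O-])c1ccc(NC(=S)OCCc2ccccn2)cc1` only a limit of the assay is reported, > 100000 nM.

Compound 1 thus holds the highest of the two plain numbers, with compound 2 nearest; the step of a 1.3-fold lower number from compound 1 to compound 2 (0.10 log units; within the scatter) is small. Compound 4 `Cc1ccc(NC(=S)OCCc2ccccn2)cc1Cl` differs from compound 1 by chloro in place of hydrogen on an aromatic carbon. The measured steps of an at least 1.3-fold higher number from compound 1 to compound 3 (0.12 log units; that floor lies within the scatter) and an at least 1.6-fold higher number from compound 2 to compound 3 (0.22 log units; that floor lies within the scatter) all swap the group on the aromatic carbon and stay within the scatter; none adds a chloro, so they bear only loosely on this change. No shift beyond the scatter is therefore expected, meaning a 1.1-fold lower number from compound 1 to compound 4 (0.03 log units; within the scatter). Compound 4 is estimated at 70000 nM, between 35000 nM and 100000 nM.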

Compound 4, half-maximal cytotoxic concentration: 59000 nM
For compound 4 the middle estimate is 1.2-fold (0.07 log units) above the measured one; measured number inside the range.
By their numbers in this assay, from the lowest: compounds 4, 2 and 1 (each within the scatter of the next). At a limit, above all of these: compound 3.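

Unlike the earlier steps, which swap one group for another, this one puts chloro where only hydrogen stood, on an aromatic carbon ortho to a methyl group and meta to a large group. In this assay the result is a 1.3-fold lower number from compound 1 to compound 4 (0.10 log units; within the scatter), so this position takes a chlorine atom without a shift beyond the scatter. Any rise in this series can be read only up to a ceiling: the limit of > 100000 nM in this assay, at which 1 of the 4 values shown sits.

From the compounds shown here alone, whether an amine or a carboxylic acid at this position would give the same result stays open. So does the outcome of chloro elsewhere on the ring.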